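The source may hold more compounds than are shown below. What is called first, only, known or untested is meant among the compounds shown, and "the series" means these compounds.

Of the compounds shown here, three built on one shared core have been tested in a functional assay on NCI-H1975 cells (Homo sapiens) for inhibition, read by MTT assay, with a stated time of 72 h; a lower number here means a stronger inhibitor, a higher number a weaker inhibitor. Compound 1 `O=C(CSc1nc(Nc2ccccc2)c2ccccc2n1)Nc1ccccc1F` carries a 2-fluorophenyl group on an amide-type nitrogen and in this assay gives 9350 nM. Compound 2 `O=C(CSc1nc(Nc2ccccc2)c2ccccc2n1)Nc1cccc(F)c1` carries a 3-fluorophenyl group at that nitrogen and gives 6790 nM. Compound 3 `C=CC(=O)Nc1cccc(NC(=O)CSc2nc(Nc3ccccc3)c3ccccc3n2)c1` carries a 3-((vinylcarbonyl)amino)phenyl group at that nitrogen and gives 8120 nM. By the bare numbers compound 3 is placed among the other two, but the step of a 1.2-fold lower number from compound 1 to compound 3 (0.06 log units; within the scatter) and the step of a 1.2-fold higher number from compound 2 to compound 3 (0.08 log units; within the scatter) are both within the scatter, as is the step of a 1.4-fold lower number from compound 1 to compound 2 (0.14 log units; within the scatter), so the three compounds cannot be told apart in this assay.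

Compound 4 `O=C(CSc1nc(Nc2ccccc2)c2ccccc2n1)Nc1ccc(Br)cc1` makes one more exchange at the same amide-type nitrogen: 4-bromophenyl in place of 3-((vinylcarbonyl)amino)phenyl on an amide-type nitrogen. The three measured steps all concern exchanges of the aromatic group on this nitrogen, and none of them moved the number beyond the scatter. For the same reason no change beyond the scatter is expected in this assay for the step of a 1.0-fold lower number from compound 3 to compound 4 (0.01 log units; within the scatter). On that basis compound 4 is estimated at 8000 nM, with a likely range from 4000 nM to 16000 nM.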

Compound 4, half-maximal inhibitory concentration: 10600 nM
Compound 4: the middle estimate sits 1.3-fold (0.12 log units) below what was measured; measured number inside the range.
By their numbers in this assay, from the lowest: compounds 2, 3, 1 and 4 (each within the scatter of the next).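

In this assay, the exchange at the amide-type nitrogen gives a 1.3-fold higher number from compound 3 to compound 4 (0.12 log units; within the scatter) as its step. This exchange removes a 3-((vinylcarbonyl)amino)phenyl group, with its hydrogen-bond donor, hydrogen-bond acceptor and double bonds outside the ring, and brings in a 4-bromophenyl group that has none of these, so a larger difference in the group than any shown before still leaves the number within the scatter. The other two new steps, a 1.6-fold higher number from compound 2 to compound 4 (0.19 log units; within the scatter) and a 1.1-fold higher number from compound 1 to compound 4 (0.05 log units; within the scatter), are also within the scatter, so all four compounds remain indistinguishable in this assay, and bromine at the 4 position joins the groups tolerated at this nitrogen without a measurable difference. Nothing shown here explains why these different groups cannot be told apart.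

On these data alone, all four compounds carry a six-membered aromatic ring of carbon only at this nitrogen, so it remains open whether a carboxylic acid or an amine on that ring, or a longer chain in place of the ring, would move the number beyond the scatter. These steps also say nothing about exchanges elsewhere on the shared core, such as on its phenylamino group.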